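From cyano to acetyl: compound 3 to compound 4

The compounds below may be only part of what the source reports. "The series", "measured", "known", "first", "only" and "open" are said of these compounds alone.

Of the compounds shown here, three with a shared core have been measured in an ADME assay on WI-38 cells (Homo sapiens) for cytotoxicity, read by MTT assay, with a stated time of 72 h; on this read-out higher numbers stand for weaker inhibition and lower numbers for stronger inhibition. Compound 1 `O=C(CCc1cccc2c1B(O)OC2)Nc1cccc(-c2ccc(Cl)cc2)c1` gives 9800 nM, compound 2 `COc1ccc(-c2cccc(NC(=O)CCc3cccc4c3B(O)OC4)c2)cc1` gives 1400 nM, and compound 3 `N#Cc1cccc(-c2cccc(NC(=O)CCc3cccc4c3B(O)OC4)c2)c1` gives 7300 nM. A step of a 1.3-fold lower number from compound 1 to compound 3 (0.13 log units; within the scatter) stays within the scatter, so these two stand level at the high end of the numbers, and a 5.2-fold higher number from compound 2 to compound 3 (0.72 log units; beyond the scatter) marks the distance from the lowest number.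

Compound 4 `CC(=O)c1cccc(-c2cccc(NC(=O)CCc3cccc4c3B(O)OC4)c2)c1` differs from compound 3 by having acetyl in place of cyano on an aromatic carbon, meta to a large group: acetyl in place of cyano on an aromatic carbon. Among the measured compounds shown here, no measured step involves acetyl, so the guidance is indirect. The remaining step, a 7.0-fold lower number from compound 1 to compound 2 (0.85 log units; beyond the scatter), is also modest and beyond the scatter, and it brings in methoxy. Both steps beyond the scatter involve compound 2, and compound 4 carries no methoxy. From the compounds shown here alone, a step beyond the scatter is therefore not expected in this assay, and the direction stays open. The estimated change is a 1.3-fold lower number from compound 3 to compound 4 (0.12 log units; within the scatter), which is expected to be a small drift at most. For compound 4 the expected value is 5500 nM, with an estimated range of 2000 nM to 13000 nM.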

Compound 4, half-maximal inhibitory concentration: 2200 nM
The estimate for compound 4 lay 2.5-fold (0.40 log units) above the measured number; the measured number falls inside the stated range.
By their numbers in this assay, from the lowest: compounds 2 and 4 (each within the scatter of the next); then compounds 3 and 1 (each within the scatter of the next).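

In this assay, exchanging cyano for acetyl on this aromatic carbon, meta to a large group, gives a 3.3-fold lower number from compound 3 to compound 4 (0.52 log units; beyond the scatter) and so shows that the group at this position can shift the number even when the change is only this small one. Methoxy is also not needed for a number at the low end of this set: compound 4 carries no methoxy, yet the comparison with the methoxy compound gives a 1.6-fold higher number from compound 2 to compound 4 (0.20 log units; within the scatter) and leaves the two level. The comparison with the chloro compound gives a 4.5-fold lower number from compound 1 to compound 4 (0.65 log units; beyond the scatter) and completes a split of the four compounds into two level pairs, with compounds 2 and 4 at the lower numbers and compounds 1 and 3 at the higher ones.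

Nothing available explains why acetyl and cyano part in this way. From the compounds shown here alone, it also remains open whether an amine or a carboxylic acid on this same aromatic carbon would join the pair with the lower numbers or the pair with the higher ones.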